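Moving a Trifluoromethyl on the Acyl Aryl Group

The source may report more compounds than this note shows. Statements on the series, on what has been measured and on what is new or still open speak of the compounds shown alone.

Three analogues of a shared core have been measured in a functional assay on MCF7 cells (Homo sapiens) for inhibition, read by MTT assay, with a stated time of 72 h; on this read-out higher numbers stand for weaker inhibition and lower numbers for stronger inhibition. Compound 1 `CN(C(=O)NC(=O)c1cccc(C(F)(F)F)c1)c1nc(C(F)(F)F)c(C(=O)N/N=C/c2ccc(C(F)(F)F)cc2)s1` gives 6.5 ug/mL. Compound 2 `CN(C(=O)NC(=O)c1ccc(C(F)(F)F)cc1)c1nc(C(F)(F)F)c(C(=O)N/N=C/c2cccc(C(F)(F)F)c2)s1` gives 8.95 ug/mL, and compound 3 `CN(C(=O)NC(=O)c1ccc(C(F)(F)F)cc1)c1nc(C(F)(F)F)c(C(=O)N/N=C/c2cc(C(F)(F)F)cc(C(F)(F)F)c2)s1` gives 7.37 ug/mL. Compound 2 holds the highest of the three numbers, but its nearest neighbour compound 3 and its furthest neighbour compound 1 both lie within the scatter of it, so no order among the three can be claimed. The only single-point step shown is a 1.2-fold lower number from compound 2 to compound 3 (0.08 log units; within the scatter), which did not move the number beyond the scatter.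

Compound 4 `CN(C(=O)NC(=O)c1cccc(C(F)(F)F)c1)c1nc(C(F)(F)F)c(C(=O)N/N=C/c2cccc(C(F)(F)F)c2)s1` has not yet been measured. It differs from compound 2 by 3-(trifluoromethyl)phenyl in place of 4-(trifluoromethyl)phenyl on a carbonyl carbon. Among the compounds with values here, no measured pair differs in exactly this way, so no step bears on it directly. Compound 1 also carries 3-(trifluoromethyl)phenyl on that carbonyl carbon, though it differs from compound 4 elsewhere, and its value sits within the scatter of compound 2. The rearrangement of the same atoms therefore gives no ground to expect a step beyond the scatter in this assay, so compound 4 is expected to show a 1.2-fold lower number from compound 2 to compound 4 (0.08 log units; within the scatter). Compound 4 is estimated at 7.5 ug/mL, within a range from 3.5 ug/mL to 16 ug/mL.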

Compound 4, half-maximal inhibitory concentration: 3.7 ug/mL
For compound 4 the middle estimate is 2.0-fold (0.31 log units) above the measured one; the range from low to high includes it.
By their numbers in this assay, from the lowest: compounds 4, 1, 3 and 2 (each within the scatter of the next, the first and the last beyond it).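

In this assay, within the data shown here, 3-(trifluoromethyl)phenyl in place of 4-(trifluoromethyl)phenyl on a carbonyl carbon whose other neighbours are amide-type nitrogen gives a 2.4-fold lower number from compound 2 to compound 4 (0.38 log units; beyond the scatter), the first step in this set to pass the scatter, so the number at this place responds to where the trifluoromethyl sits even though the atoms stay the same. The same exchange on a carbon with a double bond to nitrogen gives a 1.8-fold lower number from compound 1 to compound 4 (0.24 log units; within the scatter), so only the carbonyl place shows a step that can be told apart from repeat variation. Nothing shown here accounts for the step at the carbonyl carbon.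

Going by these compounds, the step at that carbon rests on a single pair of compounds, and whether it holds with other groups on the far side of the core stays open. Also open, on these data alone, is how a plain phenyl would read on the same carbonyl carbon, and how that ring would read with an amine or a carboxylic acid in place of the trifluoromethyl.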